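This account rests on a few compounds, and the source may have more. Where it says the series, first, only, none or still open, it means among the compounds named here.

Measured in an ADME assay on L02 cells (Homo sapiens) for cytotoxicity, read by MTT assay, with a stated time of 48 h; a higher number here means a weaker inhibitor, a lower number a stronger inhibitor:
- compound 1 `CCn1c(C(=O)NCCN(C)C)ccc1C(CC)(CC)c1ccc(OCC(=O)C(C)(C)C)c(C)c1` gives 2500 nM
- compound 2 `CCn1c(C(=O)NCCN)ccc1C(CC)(CC)c1ccc(OCC(=O)C(C)(C)C)c(C)c1` gives 2500 nM
- compound 3 `CCOC(=O)CN(C)C(=O)c1ccc(C(CC)(CC)c2ccc(OCC(O)C(C)(C)C)c(C)c2)n1CC` gives 10100 nM

Compound 3 has the highest of the three numbers. Compound 4 `CCN(CC)CCCNC(=O)c1ccc(C(CC)(CC)c2ccc(OCC(O)C(C)(C)C)c(C)c2)n1CC` has not been measured. It differs from compound 3 by one change (in words: (3-(diethylamino)propyl)amino in place of ((ethoxycarbonyl)methyl)(methyl)amino on a carbonyl carbon) ((3-(diethylamino)propyl)amino in place of ((ethoxycarbonyl)methyl)(methyl)amino on a carbonyl carbon). For the measured compounds named here, no measured step covers this exchange. Going by the values given here, the only step, no change at the digits printed from compound 1 to compound 2 (within the scatter), swaps the chain end and shows no size. Compound 1 and compound 2 both carry an amino-ended chain and have lower numbers than compound 3, but they differ from it elsewhere too. A moderate step towards a lower number is therefore expected in this assay. The expected step is a 2.9-fold lower number from compound 3 to compound 4 (0.46 log units; beyond the scatter). For compound 4 the estimated value is 3500 nM, with an expected range of 1300 nM to 9000 nM.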

Compound 4, half-maximal inhibitory concentration: 2500 nM
The estimate for compound 4 lay 1.4-fold (0.15 log units) above the measured number, within the range that was stated.
By their numbers in this assay, from the lowest: compounds 1, 2 and 4 (each within the scatter of the next); then compound 3.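

On the carbonyl carbon, this assay now gives a size for exchanging the whole substituent: (3-(diethylamino)propyl)amino in place of ((ethoxycarbonyl)methyl)(methyl)amino gives a 4.0-fold lower number from compound 3 to compound 4 (0.61 log units; beyond the scatter). For the compounds shown here, the earlier step, with no change at the digits printed from compound 1 to compound 2 (within the scatter), altered only a chain end, so this is the first sign that the number responds to what this position carries. Nothing available explains the step.

The entering and leaving groups differ at several points at once, leaving open which difference matters. A carboxylic acid in place of the ethoxycarbonyl end would test one of them.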